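The source may hold more compounds than are shown below. What is called first, only, known or untested is meant among the compounds shown, and "the series" means these compounds.

In a functional assay on HUVEC cells (Homo sapiens) for inhibition (a higher number here means a weaker inhibitor, a lower number a stronger inhibitor), three compounds that share one core have been measured. Compound 1 `COc1cc(/C=C/C(=O)c2cccc(NC(=O)c3cc(Cl)cc(Cl)c3)c2)ccc1O` gives (0.75 ug/mL), compound 2 `COc1cc(/C=C/C(=O)c2cccc(NC(=O)c3ccco3)c2)ccc1O` gives (0.38 ug/mL), and compound 3 `COc1cc(/C=C/C(=O)c2cccc(NC(=O)c3ccc(Cl)cc3Cl)c2)ccc1O` gives (0.4 ug/mL). Compound 3 therefore stands within a close group, as no gap among the three goes beyond the scatter. Compound 4 `COc1cc(/C=C/C(=O)c2cccc(NC(=O)C(C)C)c2)ccc1O` carries isopropyl in place of 2,4-dichlorophenyl on a carbonyl carbon. Three measured steps changed the group at this same place (a 1.1-fold higher number from compound 2 to compound 3 (0.02 log units; within the scatter)) and (a 1.9-fold lower number from compound 1 to compound 3 (0.27 log units; within the scatter)) and (a 2.0-fold lower number from compound 1 to compound 2 (0.30 log units; within the scatter)), and each lies within the scatter. All three exchanged one ring for another, whereas isopropyl has no ring, so they guide the expectation only loosely. Starting from compound 3 at (0.4 ug/mL) and with those steps so small, no step beyond the scatter is expected in this assay, with only a slight lean towards a higher number. The expected step is (a 1.4-fold higher number from compound 3 to compound 4 (0.14 log units; within the scatter)). For compound 4 the estimated value is 0.55 ug/mL with an expected range (from 0.22 ug/mL to 1.4 ug/mL).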

Compound 4, half-maximal inhibitory concentration: 1.44 ug/mL
Beside the measured number, compound 4's estimate is 2.6-fold (0.42 log units) below it; measured number above the stated range.
By their numbers in this assay, from the lowest: compounds 2, 3, 1 and 4 (each within the scatter of the next, the first and the last beyond it).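

The position proves not to be indifferent to its group in this assay. Going by these compounds alone, replacing a ring with isopropyl on this carbonyl carbon produces the first steps beyond the scatter, both modest, (a 3.6-fold higher number from compound 3 to compound 4 (0.56 log units; beyond the scatter)) and (a 3.8-fold higher number from compound 2 to compound 4 (0.58 log units; beyond the scatter)). Compound 1 goes against any simple split between ring and no ring, since the same change from 3,5-dichlorophenyl stays within the scatter (a 1.9-fold higher number from compound 1 to compound 4 (0.28 log units; within the scatter)).

No measurement given here explains these steps.

The compounds shown leave open whether the ring itself matters or some other difference between these groups, as a cyclohexyl group or an unsubstituted phenyl would be needed to separate the two. As far as these compounds go, how a longer chain or an amine would behave at this place also remains open.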